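Anilide ring substituent: methyl to methoxy in the series

The source may report more compounds than this note shows. Statements on the series, on what has been measured and on what is new or still open speak of the compounds shown alone.

Compound 2, `Cc1ccccc1NC(=O)CCC(=O)OCCCCCCSc1ccc([N+](=O)[O-])c2nonc12`, carries a methyl on the aromatic ring of the anilide part of the shared core. Going by the values given here, in an assay on isolated protein for inhibition of glutathione S-transferase P (Homo sapiens), with a stated time of 10 min (on this read-out lower numbers stand for stronger inhibition and higher numbers for weaker inhibition), compound 2 gives 4100 nM, the lowest of the two numbers measured so far. Its nearest neighbour is compound 1, `O=C(CCC(=O)OCCCCCCSc1ccc([N+](=O)[O-])c2nonc12)Nc1ccccc1`, which lacks that methyl; in this assay compound 1 gives 10200 nM. Among the compounds with values here, the only measured step, a 2.5-fold lower number from compound 1 to compound 2 (0.40 log units; beyond the scatter), shows that putting a methyl on that aromatic carbon is worth a modest gain.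

Compound 3, `COc1ccccc1NC(=O)CCC(=O)OCCCCCCSc1ccc([N+](=O)[O-])c2nonc12`, continues from compound 2 by a single change: methoxy in place of methyl on an aromatic carbon. Within the data shown here, no measured step compares a methoxy with a methyl on this ring, so the step from compound 1 to compound 2 bears on it only indirectly, as a sign that this ring position tolerates a small group. The step from compound 2 to compound 3 in this assay is therefore expected to be small, a 1.1-fold higher number from compound 2 to compound 3 (0.04 log units; within the scatter), in either direction and within the scatter. The estimate for compound 3 in this assay is 4500 nM, with a range from 1500 nM to 13000 nM.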

Compound 3, half-maximal inhibitory concentration: 4050 nM
Compound 3: the middle estimate sits 1.1-fold (0.05 log units) above what was measured; the range from low to high includes it.
By their numbers in this assay, from the lowest: compounds 3 and 2 (each within the scatter of the next); then compound 1.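

In this assay, methyl and methoxy read alike on this aromatic carbon, ortho to a large group (a 1.0-fold lower number from compound 2 to compound 3 (0.01 log units; within the scatter)). The gain over hydrogen is therefore not peculiar to methyl: methoxy also clears the scatter (a 2.5-fold lower number from compound 1 to compound 3 (0.40 log units; beyond the scatter)), so this position accepts a group with an oxygen and one more heavy atom with no measurable loss. Nothing on hand accounts for why the two groups read alike.

Still open, going by these compounds, is whether an amine, a carboxylic acid or a longer chain such as ethoxy on this carbon would keep the same reading. Also open, on these data alone, is whether methyl and methoxy would read alike elsewhere on this ring, or whether a larger group here would go beyond the level shared by compound 2 and compound 3.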